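The source may report more compounds than this note shows. Statements on the series, on what has been measured and on what is new or still open speak of the compounds shown alone.

Measured so far:
compound 1, `CC(=O)N1c2ccccc2CCC1C(=O)Nc1cc(C(F)(F)F)cc(C(F)(F)F)c1`: > 70000 nM
compound 2, `CCC(=O)N1c2ccccc2CCC1C(=O)Nc1cc(C(F)(F)F)cc(C(F)(F)F)c1`: 7720 nM

In a functional assay on ACHN cells (Homo sapiens) for cytotoxicity, read by sulforhodamine B assay, with a stated time of 72 h (a higher number here means a weaker inhibitor of growth, a lower number a stronger inhibitor of growth), compound 1 gives a limit of the assay and no number, > 70000 nM. In this assay, for the measured compounds named here, compound 2 gives 7720 nM, the only number in hand. The other value is a limit, (the limit of > 70000 nM in this assay, at which 1 of the 2 values shown sits). Going by the values given here, the step of an at least 9.0-fold lower number from compound 1 to compound 2 (0.95 log units; beyond the scatter) is thus the sole measured step, and its size is a lower bound only. Compound 3, `O=C(Nc1cc(C(F)(F)F)cc(C(F)(F)F)c1)C1CCc2ccccc2N1C(=O)c1ccccc1`, is not yet measured; it differs from compound 2 by phenyl in place of ethyl on a carbonyl carbon. The step from compound 1 to compound 2 also enlarged the same acyl group, and the change to benzoyl enlarges it further. Because an at least 9.0-fold lower number from compound 1 to compound 2 (0.95 log units; beyond the scatter) pointed to a lower number as the acyl group grew, a further lowering is expected, though one step gives little guidance on size. Compound 3 is estimated at 3000 nM in this assay, within 700 nM to 15000 nM, an expected step of a 2.6-fold lower number from compound 2 to compound 3 (0.41 log units; beyond the scatter).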

Compound 3, concentration for 50% growth inhibition: 2920 nM
Beside the measured number, compound 3's estimate is 1.0-fold (0.01 log units) above it; the measured number falls inside the stated range.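

At this carbonyl carbon, an aromatic ring is tolerated in this assay and the number keeps falling: a 2.6-fold lower number from compound 2 to compound 3 (0.42 log units; beyond the scatter) shows that the trend is not confined to saturated groups. Across methyl, ethyl and phenyl at this place, the number falls at each step, no compound shown goes against this, and the overall span is an at least 23-fold lower number from compound 1 to compound 3 (1.37 log units; beyond the scatter). That span is a lower bound only, since compound 1 gives a limit of the assay and no number: the limit of > 70000 nM in this assay, at which 1 of the 3 values shown sits.

On these data alone, whether the lower number follows the aromatic ring or merely the larger group stays open; a longer chain such as butanoyl, or a saturated cyclohexyl on the same carbonyl carbon, would separate the two. Also open, as far as these compounds go, is how a phenyl ring carrying a methoxy group or an amine would read.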